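Chloro to Methyl on a Well-Dissolving Series

A few compounds are considered here, and "the series" means these few. Any claim that something is new, unique, unknown or untested is made for them only; others in the source may bear on it.

Of the compounds shown here, three sharing one core have been measured in a physicochemical assay for solubility, measured as kinetic solubility; on this read-out lower numbers stand for lower solubility and higher numbers for higher solubility. Compound 1 `CNC(=O)c1cc(C(=O)N[C@H]2CC[C@H](O)CC2)c([C@@H](C)c2cccc(Cl)c2)o1` carries a 1-(3-chlorophenyl)ethyl group; in this assay compound 1 gives >= 179 ug/mL, which is a limit of the assay and not a number. Compound 2 `CNC(=O)c1cc(C(=O)N[C@H]2CC[C@H](O)CC2)c([C@@H](C)c2cccc(C)c2)o1` gives >= 172 ug/mL in this assay, again a limit. Compound 3 `CNC(=O)c1cc(C(=O)N[C@H]2CC[C@H](O)CC2)c([C@@H](C)c2ccc(Cl)cc2)o1` gives >= 118 ug/mL in this assay, also a limit. Since all three values are limits, the steps between them cannot be read: a step that the two limits leave unreadable from compound 1 to compound 2, a step that the two limits leave unreadable from compound 1 to compound 3 and a step that the two limits leave unreadable from compound 2 to compound 3.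

The unmeasured compound 4 `CNC(=O)c1cc(C(=O)N[C@H]2CC[C@H](O)CC2)c([C@@H](C)c2ccc(C)cc2)o1` differs from compound 3 by methyl in place of chloro on an aromatic carbon. The same change, from compound 1 to compound 2, is methyl in place of chloro on an aromatic carbon, and its step was a step that the two limits leave unreadable from compound 1 to compound 2. The two cores differ in that compound 3 differs from compound 1 by 4-chlorophenyl in place of 3-chlorophenyl on a saturated chain carbon bound to an aromatic carbon and a saturated chain carbon. The surroundings are not identical: in compound 1 the group sits meta to a large group, in compound 3 para to a large group, so the change is the same kind of change rather than the same.

With every neighbour at a limit (the limit of >= 118 ug/mL in this assay, at which 1 of the 3 values shown sits, (the limit of >= 172 ug/mL in this assay, at which 1 of the 3 values shown sits), (the limit of >= 179 ug/mL in this assay, at which 1 of the 3 values shown sits)), the expected step is a step that the limit leaves unreadable from compound 3 to compound 4, and compound 4 is expected to reach about 165 ug/mL, most likely reported as a limit as well.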

Compound 4, solubility: >= 245 ug/mL
Compound 4 ended at the assay's limit (the forecaster's own chance of this, stated with the estimate: 75%); middle value at least 1.4-fold (0.17 log units) from the limit.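

Compound 4 also gives a limit of the assay and not a number in this assay: the limit of >= 245 ug/mL in this assay, at which 1 of the 4 values shown sits. Compound 1, compound 2 and compound 3 stand at limits too, so no step between any of these compounds can be read. Still open, going by these compounds, is how far each true value lies past its limit, and so whether methyl in place of chloro on an aromatic carbon changes the read-out at all, in either compound 1 and compound 2 or compound 3 and compound 4.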